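This account rests on a few compounds, and the source may have more. Where it says the series, first, only, none or still open, it means among the compounds named here.

Measured compounds:
compound 1 `COc1ccc2[nH]c3c(c2c1)CCNC31CCN(Cc2cc(Cl)ccc2[N+](=O)[O-])CC1`: 7100 nM
compound 2 `COc1ccc2[nH]c3c(c2c1)CCNC31CCN(Cc2ccc(Cl)cc2Cl)CC1`: 1800 nM

Of the compounds shown here, two have been measured in an assay on FRT cells for positive allosteric modulation of Cystic fibrosis transmembrane conductance regulator variant N1303K (Homo sapiens), in the presence of a further agent that is not named here; a higher number here means that more compound is needed for the effect, a lower number that less compound is needed. Going by the values given here, compound 2 stands lowest of the two numbers; its only neighbour is compound 1, and the step of a 3.9-fold lower number from compound 1 to compound 2 (0.60 log units; beyond the scatter) was modest but beyond the scatter. Compound 3 `COc1ccc2[nH]c3c(c2c1)CCNC31CCN(Cc2cc(F)cc(Cl)c2)CC1` has not yet been measured. It differs from compound 2 by 3-chloro-5-fluorophenyl in place of 2,4-dichlorophenyl on a saturated chain carbon bound to an amine nitrogen in a ring. Among the compounds with values here, the single measured step that bears on this change, a 3.9-fold lower number from compound 1 to compound 2 (0.60 log units; beyond the scatter), exchanged the whole aryl group on the same saturated carbon and showed that this group influences the read-out modestly. Here both rings are halogenated and of equal size, so no direction is firmly indicated. The expected step is a 1.4-fold higher number from compound 2 to compound 3 (0.14 log units; within the scatter), estimated to be small and within the scatter, if anything a slight rise. The estimate for compound 3 is 2500 nM, with an expected range from 1000 nM to 7000 nM.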

Compound 3, half-maximal effective concentration: 2500 nM
Beside the measured number, compound 3's estimate shows no gap at the digits printed; the measured number falls inside the stated range.
By their numbers in this assay, from the lowest: compounds 2 and 3 (each within the scatter of the next); then compound 1.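

In this assay, 3-chloro-5-fluorophenyl and 2,4-dichlorophenyl cannot be told apart on this saturated chain carbon: the change gives a 1.4-fold higher number from compound 2 to compound 3 (0.14 log units; within the scatter), so this exchange of halogens and their places on the ring leaves the read-out unresolved. Taking 5-chloro-2-nitrophenyl as the reference gives a 2.8-fold lower number from compound 1 to compound 3 (0.45 log units; beyond the scatter), which shows that a second halogenated aryl group without the nitro group also lies beyond the scatter from compound 1, in the same direction as the earlier step. Nothing available here explains these numbers.

It remains open whether any halogen is needed at all, since an unsubstituted phenyl, or a ring carrying a methoxy or nitrile group, does not appear among these compounds. On these data alone, whether a longer chain in place of the single saturated carbon would keep the number is equally open.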